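A second trifluoromethyl on a compound held at a limit

A few compounds are considered here, and "the series" means these few. Any claim that something is new, unique, unknown or untested is made for them only; others in the source may bear on it.

Measured so far in a functional assay on RXF 393 cells (Homo sapiens) for inhibition, read by sulforhodamine B assay, with a stated time of 48 h (a higher number here means that more compound is tolerated, a lower number that less compound is tolerated), on these cells:
- Compound 1 `O=C(Nc1cccc(-n2cc(-c3ccncc3)c(-c3ccc(Cl)c(O)c3)n2)c1)Nc1cccc(C(F)(F)F)c1` gives > 32500 nM as a limit
- Compound 2 `O=C(Nc1cccc(-n2cc(-c3ccncc3)c(-c3ccc(Cl)c(O)c3)n2)c1)Nc1ccc(Cl)c(Cl)c1` gives > 32500 nM as a limit

Compound 1 stands only at a limit (> 32500 nM) and has no number of its own. Compound 2 also stands only at a limit (> 32500 nM) and likewise has no number. All that is known so far is the limit of > 32500 nM in this assay, at which 2 of the 2 values shown sit, and nothing more.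

Compound 3 `O=C(Nc1cccc(-n2cc(-c3ccncc3)c(-c3ccc(Cl)c(O)c3)n2)c1)Nc1cc(C(F)(F)F)cc(C(F)(F)F)c1` is built from compound 1 by one change trifluoromethyl in place of hydrogen on an aromatic carbon in which trifluoromethyl takes the place of hydrogen on an aromatic carbon, meta to a trifluoromethyl group. Going by the values given here, only one measured step bears on it, namely a step that the two limits leave unreadable from compound 1 to compound 2 and so it offers no size to carry over. No shift beyond the usual scatter is therefore expected in either direction in this assay for this change, and another limit is the likely report. The step expected is a number no higher from compound 1 to compound 3 (the limit leaves the size open) on this estimate. For compound 3 the estimate is 32500 nM with an expected range from 15000 nM to 60000 nM in this reading.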

Compound 3, concentration lethal to 50% of the cells: 10700 nM
The estimate for compound 3 lay 3.0-fold (0.48 log units) above the measured number, outside the stated range (below it).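

In this assay, going by these compounds alone, the one earlier step, between two compounds held at a limit, cannot be read, so the series had so far given no size for any change. Placing a second trifluoromethyl on the six-membered aromatic ring of carbon only, meta to the trifluoromethyl group already there, gives the first readable step: an at least 3.0-fold lower number from compound 1 to compound 3 (0.48 log units; beyond the scatter). This shows that the position is not silent in this assay and that this change brings the series down to a number, although the true size of the step stays open, since the starting point is only a limit, and compound 3 is the only compound shown with a number of its own: the limit of > 32500 nM in this assay, at which 2 of the 3 values shown sit.

The compounds shown leave open whether the drop belongs to trifluoromethyl itself or would also follow from a different group at this place, such as a nitrile or a methoxy group. They also leave open whether the same change would give a step of similar size on a compound whose starting value is a number and not a limit.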